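Adding bromo to compound 2

The source may hold more compounds than are shown below. What is called first, only, known or untested is meant among the compounds shown, and "the series" means these compounds.

Values from a functional assay on U-251 cells (Homo sapiens) for cytotoxicity, read by sulforhodamine B assay, with a stated time of 48 h (a lower number here means a stronger inhibitor, a higher number a weaker inhibitor), follow
Compound 1 `CC1(C)CNC(=O)c2cc(-c3ccc([N+](=O)[O-])cc3)n(-c3ccc(Br)cc3)c2C1` gives 25600 nM
Compound 2 `CC1(C)CNC(=O)c2cc3n(c2C1)CCc1ccccc1-3` gives > 100000 nM as a limit

In this assay compound 2 gives > 100000 nM as a limit of the assay, not a number. Compound 3 `CC1(C)CNC(=O)c2cc3n(c2C1)CCc1cc(Br)ccc1-3` carries the change bromo in place of hydrogen on an aromatic carbon as bromo in place of hydrogen on an aromatic carbon. Going by the values given here, compound 1, which also bears bromo, gives 25600 nM as the only number so far. A modest shift towards a stronger inhibitor is therefore expected, an estimated at least 1.4-fold lower number from compound 2 to compound 3 (0.15 log units; that floor lies within the scatter) in size, and a report of only a limit remains possible. For compound 3 the estimated value is 70000 nM with a range from 25000 nM to 150000 nM in this assay.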

Compound 3, half-maximal inhibitory concentration: 18100 nM
The estimate for compound 3 lay 3.9-fold (0.59 log units) above the measured number; measured number below the stated range.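

Bromo in place of hydrogen on this aromatic carbon, part of a fused system of four rings, gives an at least 5.5-fold lower number from compound 2 to compound 3 (0.74 log units; beyond the scatter) in this assay. A single bromine on this ring is therefore enough to bring the core of compound 2 from a limit to a measured number. The step is a floor rather than a full size, since compound 2 is reported only as a limit: the limit of > 100000 nM in this assay, at which 1 of the 3 values shown sits.

On these data alone, whether chloro, methoxy or an amine at this aromatic carbon would shift the number the same way remains open. So does the outcome of bromo on the other carbons of this ring.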